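The source may report more compounds than this note shows. Statements on the series, on what has been measured and on what is new or still open speak of the compounds shown alone.

Measured compounds:
Compound 1, `CCCSc1nc(N)c(N(CCC)CCC)c(=O)n1CC`, in a functional assay on cardiac atrium (Cavia porcellus) (a higher number here means that more compound is needed for the effect, a lower number that less compound is needed), gives 600 nM.
Compound 2, `CCCSc1nc(NC(C)=O)c(N(CCC)CCC)c(=O)[nH]1`, in this assay gives 280 nM.

Compound 2 stands at the lower of the two numbers. Within the data shown here, compound 1 and compound 2 differ in two places at once, so no single step joins them; their values alone show that compound 2 needs less compound than compound 1 by a gap beyond the usual scatter.

Compound 3, `CCCSc1nc(NC(C)=O)c(N(CCC)CCC)c(=O)n1CC`, has not yet been tested in this assay. It differs from compound 2 in one place: ethyl in place of hydrogen on an aromatic nitrogen. Among the measured compounds shown here, with no measured pair that differs in this one place, the direction of the step cannot be read from the numbers in hand. For the measured compounds named here, compound 1, the only compound carrying the ethyl on that ring nitrogen, sits at the higher value, but its other difference from compound 2 leaves that open.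

Compound 3 is therefore expected to give a value close to that of compound 2, with at most a small rise, so that the step of a 1.4-fold higher number from compound 2 to compound 3 (0.15 log units; within the scatter) stays within or just beyond the scatter. The estimate for compound 3 is 400 nM, with a range from 120 nM to 1300 nM.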

Compound 3, half-maximal effective concentration: 530 nM
The estimate for compound 3 lay 1.3-fold (0.12 log units) below the measured number, and the stated range covers the measured number.
By their numbers in this assay, from the lowest: compounds 2, 3 and 1 (each within the scatter of the next, the first and the last beyond it).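

In this assay, among these compounds, ethyl in place of hydrogen on the aromatic nitrogen, ortho to the propylsulfanyl group and para to the acetamido group, gives a 1.9-fold higher number from compound 2 to compound 3 (0.28 log units; within the scatter), the first reading of this change at this position with nothing else altered, and it shows that the two compounds cannot be told apart in this read-out. Acetyl in place of hydrogen on the nitrogen on the aromatic ring, with the ethyl held in place, gives a 1.1-fold lower number from compound 1 to compound 3 (0.05 log units; within the scatter), so this second change, read alone for the first time, also stays inside the scatter, and neither single change can be singled out as setting the number. No measurement here bears on what lies behind these two steps.

Whether a propyl chain, a benzyl group or a chain ending in a carboxylic acid on that aromatic nitrogen would carry the number beyond the scatter remains open, since ethyl is the only group shown there besides hydrogen. Equally open, as far as these compounds go, is whether a benzoyl group or a methylsulfonyl group on the nitrogen of the amine would do so, and whether either step would keep its size with a different group in place of the propylsulfanyl group.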